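Swapping the Fluoropyridine for a Trifluoromethylphenyl Group

The source may hold more compounds than are shown below. What is called first, only, known or untested is meant among the compounds shown, and "the series" means these compounds.

Compound 2 `Cc1cc(NC(=O)Cn2nnc(-c3cccc(F)n3)n2)n(C2CCCCC2)n1` carries a 6-fluoropyridin-2-yl group on the shared core. In an assay on HEK293 cells for activation of Kir3.1/Kir3.2 (Homo sapiens), read by thallium flux (a lower number here means that less compound is needed, a higher number that more compound is needed for the effect), compound 2 gives only a limit, > 3000 nM, not a number. Compound 1 `Cc1cc(NC(=O)Cn2nnc(-c3cccc(Cl)c3)n2)n(C2CCCCC2)n1`, bearing 3-chlorophenyl at the same place, gives 300 nM in this assay. Among the measured compounds shown here, the one measured step runs from compound 1 to compound 2 as an at least 10-fold higher number from compound 1 to compound 2 (1.00 log units; beyond the scatter). Compound 3 `Cc1cc(NC(=O)Cn2nnc(-c3cccc(C(F)(F)F)c3)n2)n(C2CCCCC2)n1` carries the change (3-(trifluoromethyl)phenyl in place of 6-fluoropyridin-2-yl on an aromatic carbon), restoring a carbon-only ring like that of compound 1. Compound 3 is therefore expected to recover much of that loss, with an estimated value near 500 nM (range 150 nM to 2500 nM). This expected step is an at least 6.0-fold lower number from compound 2 to compound 3 (0.77 log units; beyond the scatter).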

Compound 3, half-maximal effective concentration: 183 nM
Compound 3: the middle estimate sits 2.7-fold (0.44 log units) above what was measured, within the range that was stated.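

On this position of the shared core, 3-(trifluoromethyl)phenyl in place of 6-fluoropyridin-2-yl gives an at least 16-fold lower number from compound 2 to compound 3 (1.21 log units; beyond the scatter) in this assay. On these data alone, compound 2 gives only a limit, not a number, so the full size of this step stays unknown: the limit of > 3000 nM in this assay, at which 1 of the 3 values shown sits. Trifluoromethyl in place of chloro gives a 1.6-fold lower number from compound 1 to compound 3 (0.21 log units; within the scatter), so compound 1 and compound 3 cannot be told apart.

Still open, as far as these compounds go, is whether the ring nitrogen or the change of ring substituent accounts for the difference from compound 2. A phenyl ring bearing fluorine, or a pyridine ring bearing chlorine, would separate the two.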